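Piperidin-1-yl in Place of Amino: An Expected Gain

The source may hold more compounds than are shown below. What is called first, only, known or untested is meant among the compounds shown, and "the series" means these compounds.

Of the compounds shown here, three on a shared core have been measured in an assay on isolated protein for binding affinity to corticotropin-releasing factor receptor 1 (Homo sapiens); a lower number here means a stronger inhibitor, a higher number a weaker inhibitor. Compound 1 `CCCN(Cc1ccccc1)c1cc(C)nc2c(-c3ncc(C(F)(F)F)cc3Cl)c(C)nn12` gives 1.7 nM in this assay. Compound 2 `CCCN(CCC)c1cc(C)nc2c(-c3ncc(C)cc3[N+](=O)[O-])c(C)nn12` gives 14 nM. Compound 3 `CCCN(CCC)c1cc(C)nc2c(-c3ncc(N)cc3C)c(C)nn12` gives 85 nM, the highest number of the three; compound 2 stands nearest to it with a lower number, and compound 1 furthest with a much lower number, both gaps lying beyond the scatter. No pair among these three differs in one place only, so no single step between measured compounds can be drawn from them.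

Compound 4 `CCCN(CCC)c1cc(C)nc2c(-c3ncc(N4CCCCC4)cc3C)c(C)nn12` has not yet been measured. It differs from compound 3 in one place: piperidin-1-yl in place of amino on an aromatic carbon. Among the measured compounds shown here, no measured step of this kind exists here, so the expectation rests only on the spread of the measured numbers. The change is expected to move compound 4 downward, toward the lower numbers of the other two compounds, by a step beyond the scatter. The expected step is a 4.3-fold lower number from compound 3 to compound 4 (0.63 log units; beyond the scatter). Compound 4 is therefore estimated at 20 nM in this assay, within a range from 5 nM to 80 nM.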

Compound 4, inhibition constant: 17 nM
Compound 4: middle estimate off by 1.2-fold (0.07 log units), on the high side; the measured number falls inside the stated range.
By their numbers in this assay, from the lowest: compound 1; then compounds 2 and 4 (each within the scatter of the next); then compound 3.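

In this assay, the step at this position, a 5.0-fold lower number from compound 3 to compound 4 (0.70 log units; beyond the scatter), is modest but lies beyond the scatter, and it shows that the aromatic carbon two atoms from the ring nitrogen can carry far more than amino: piperidin-1-yl brings 6 heavy atoms and a six-membered non-aromatic ring where 1 heavy atom stood, and the number still falls. The same change also removes the hydrogen-bond donor of amino, and this single step cannot separate that loss from the gain of the ring. Nothing available here bears on why the number moves as it does.

The compounds shown leave open whether an open-chain amine such as dimethylamino, or a ring with a second hetero atom such as morpholin-4-yl, would lower the number as far as piperidin-1-yl does. They also leave open whether the same change would give a step of similar size with a different group in place of the methyl group on this ring, or with a different amine in place of the dipropylamino group on the shared core.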